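Replacing methyl with ethynyl in compound 3

The source may hold more compounds than are shown below. What is called first, only, known or untested is meant among the compounds shown, and "the series" means these compounds.

Compound 1 `COc1ccc(F)cc1N1C(=O)CSC1c1cccc(C(=O)NCCCCn2cccn2)c1`: 1310 mL.min-1.g-1
Compound 2 `COc1ccccc1N1C(=O)CSC1c1cc(F)cc(C(=O)NCCCCc2ccccc2)c1`: 1430 mL.min-1.g-1
Compound 3 `Cc1cccc(N2C(=O)CSC2c2cccc(C(=O)NCCCCc3ccccc3)c2)c1`: 2940 mL.min-1.g-1

These values come from an ADME assay on microsomes from liver (Mus musculus) for metabolic stability, read by LC-MS, using NADPH, with a stated time of 10 min, tested at 0.1 uM; on this read-out higher numbers stand for fast clearance and lower numbers for slow clearance. Compound 3 stands highest of the three, and compound 1 and compound 2 both lie lower by more than the usual scatter. Compound 4 `C#Cc1cccc(N2C(=O)CSC2c2cccc(C(=O)NCCCCc3ccccc3)c2)c1` has ethynyl in place of methyl on an aromatic carbon, meta to a large group (ethynyl in place of methyl on an aromatic carbon). Within the data shown here, no measured pair shows this change. With compound 3 at 2940 mL.min-1.g-1, already the highest number, a slight fall is expected, and no step beyond the scatter is anticipated in this assay: the expected change is a 1.3-fold lower number from compound 3 to compound 4 (0.13 log units; within the scatter). Compound 4 is estimated at 2200 mL.min-1.g-1, with an expected range of 1100 mL.min-1.g-1 to 4200 mL.min-1.g-1.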

Compound 4, intrinsic clearance in microsomes: 1900 mL.min-1.g-1
For compound 4 the middle estimate is 1.2-fold (0.06 log units) above the measured one; measured number inside the range.
By their numbers in this assay, from the lowest: compounds 1, 2, 4 and 3 (each within the scatter of the next, the first and the last beyond it).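

In this assay the swap of methyl for ethynyl on this aromatic carbon, meta to a large group, gives a 1.5-fold lower number from compound 3 to compound 4 (0.19 log units; within the scatter). Among these compounds, this is the only pair here that differs in one place, and it shows that 3-methylphenyl and 3-ethynylphenyl cannot be told apart on this read-out. Nothing measured here bears on the reason for this result. On these data alone, whether an amine, a carboxylic acid or a longer chain on this carbon would move clearance beyond the scatter remains open. So does whether the same swap behaves alike with a different amide chain.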